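A larger amine-bearing group on the shared core

The source may hold more compounds than are shown below. What is called first, only, known or untested is meant among the compounds shown, and "the series" means these compounds.

In a functional assay for antagonist activity, with Cavia porcellus as the target (a higher number here means a weaker inhibitor, a lower number a stronger inhibitor), compound 1 (`CCN(CC)CC#CCCC1(C(O)(c2ccccc2)c2ccccc2)SCCCS1`) gives 500 nM; 500 nM (2 entries) in both entries. Compound 2 (`CCN(C)CC#CCCC1(C(O)(c2ccccc2)c2ccccc2)SCCCS1`) gives 1230 nM, the higher of the two numbers. Compound 3 (`CCN(CC)CC#CCCCC1(C(O)(c2ccccc2)c2ccccc2)SCCCS1`) has not yet been measured, and it differs from compound 2 by a group of 9 heavy atoms (8 carbon, 1 nitrogen; no ring) in place of a group of 7 heavy atoms (6 carbon, 1 nitrogen; no ring), on a saturated chain carbon, two bonds along the chain from a saturated ring carbon. Among the compounds with values here, no measured step speaks directly to this change. With compound 1 at 500 nM; 500 nM (2 entries) as the only other reference, a modest fall in the number is expected, close to the scatter. The expected change is a 1.8-fold lower number from compound 2 to compound 3 (0.24 log units; within the scatter). For compound 3 the estimate is 700 nM, within an expected range of 250 nM to 2000 nM.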

Compound 3, antagonist equilibrium constant: 810 nM
For compound 3 the middle estimate is 1.2-fold (0.06 log units) below the measured one, and the stated range covers the measured number.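

In this assay the 4-(diethylamino)but-2-yn-1-yl group, on a saturated chain carbon, two bonds along the chain from a saturated ring carbon, gives a 1.5-fold lower number from compound 2 to compound 3 (0.18 log units; within the scatter) and so stays within the scatter. This position therefore takes the group of 9 heavy atoms in place of the group of 7 with no clear shift in the number. No measurement at hand accounts for this result. The compounds shown leave open how a pyrrolidine or piperidine in place of the diethylamino group would read in this assay and what a longer chain would do here.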